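Swapping a dimethoxyphenyl for fluorophenyl on the saturated carbon

This account rests on a few compounds, and the source may have more. Where it says the series, first, only, none or still open, it means among the compounds named here.

The study examined a small set of trimethoxyphenyl compounds in a functional assay on BGC-823 cells (Homo sapiens) for antiproliferative activity, read by MTT assay, tested at 5 uM; on this read-out higher numbers stand for a stronger effect at the one concentration tested and lower numbers for a weaker effect. Compound 1, `COc1cc(C2=NN(C(C)=O)C(c3cccc(OC)c3OC)O2)cc(OC)c1OC`, carries a 2,3-dimethoxyphenyl group on a saturated carbon of its five-membered ring; in this assay compound 1 gives 17.5%. For the measured compounds named here, the only other compound with a number so far is compound 2, `COc1cc(/C=N/NC(=O)c2cc(OC)c(OC)c(OC)c2)cc(OC)c1OC`, an open-chain hydrazone, and in this assay compound 2 gives 22.9%. Going by the values given here, the two numbers lie within the scatter of each other, so nothing separates them, and no step between measured compounds is available to anchor a trend.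

Compound 3, `COc1cc(C2=NN(C(C)=O)C(c3cccc(F)c3)O2)cc(OC)c1OC`, keeps the shared core of compound 1 and changes one place: 3-fluorophenyl in place of 2,3-dimethoxyphenyl on a saturated ring carbon. Among the compounds with values here, with no measured step to build on, the expectation is modest: a change no larger than the scatter, in either direction. The estimate for compound 3 is therefore 20%, within the range 5% to 40%, which means an expected step of a number 2.5 percentage points higher from compound 1 to compound 3 (within the scatter).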

Compound 3, a percentage reported as inhibition, at one concentration (the size of the read-out at that concentration, not a potency): 37.7%
Compound 3: the middle estimate sits 17.7 percentage points below what was measured; low and high end bracket the measured number.
By their numbers in this assay, from the lowest: compounds 1 and 2 (each within the scatter of the next); then compound 3.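

For the compounds shown here, until this result no step existed, so it could not be said whether the saturated ring carbon of the shared core mattered at all in this assay; 3-fluorophenyl in place of 2,3-dimethoxyphenyl gives a number 20.2 percentage points higher from compound 1 to compound 3 (beyond the scatter) at this position. The place is therefore not silent, and the read-out there does not depend on keeping the 2,3-dimethoxyphenyl group, since the smaller 3-fluorophenyl, with 0 hydrogen-bond acceptors against 2, gives the higher number of this pair. Nothing measured here says what lies behind this rise.

Going by these compounds alone, the single step leaves open whether the higher number belongs to the fluorine, to where it sits on the phenyl ring, or simply to the departure of the two methoxy groups, and an unsubstituted phenyl on the same carbon would begin to separate these. Also open, from the compounds shown here alone, is how this carbon would respond to a different kind of group, such as a phenyl ring bearing an amine or a carboxylic acid, or a longer chain in place of the ring.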